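Aryl Replaces Alkylamino on the Shared Core

The compounds below may be only part of what the source reports. "The series", "measured", "known", "first", "only" and "open" are said of these compounds alone.

compound 1 `CCCCCNc1nn2c(=O)cc(C(F)(F)F)nc2s1` – 760 nM
compound 2 `CCCCN(CCCC)c1nn2c(=O)cc(C(F)(F)F)nc2s1` – 4630 nM

In an ADME assay on cells for inhibition of Intestinal-type alkaline phosphatase (Homo sapiens), read by luminescence, with stated times of 7 min and 20 min (a lower number here means a stronger inhibitor, a higher number a weaker inhibitor), compound 1 gives 760 nM, the lowest of the two numbers. Its nearest neighbour is compound 2, which in this assay gives 4630 nM, a gap beyond the usual scatter. Compound 3 `O=c1cc(C(F)(F)F)nc2sc(-c3ccccc3F)nn12` has not yet been measured. Relative to compound 1 it carries 2-fluorophenyl in place of pentylamino on an aromatic carbon. Within the data shown here, no measured pair shows a swap of this kind, so the direction rests on no direct precedent; a weakening step of moderate size is expected rather than none. Compound 3 is expected to give 2000 nM, in the range 400 nM to 10000 nM. The expected step is a 2.6-fold higher number from compound 1 to compound 3 (0.42 log units; beyond the scatter).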

Compound 3, half-maximal inhibitory concentration: > 100000 nM
Compound 3 was reported as a limit; the forecaster's own chance of this, stated with the estimate: 10%; middle value at least 50-fold (1.69 log units) from the limit.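

Compound 3 gives > 100000 nM in this assay, which is a limit of the assay and not a number: the limit of > 100000 nM in this assay, at which 1 of the 3 values shown sits. Compound 1 and compound 2, both with an amine nitrogen on this aromatic carbon, give measured numbers. Putting 2-fluorophenyl in place of pentylamino there gives an at least 130-fold higher number from compound 1 to compound 3 (2.11 log units; beyond the scatter), so this single change at this position is enough to reach the limit.

The compounds shown do not tell whether the loss follows the departing amine nitrogen or the entering aromatic ring. A plain pentyl chain or a phenylamino group on this carbon would separate the two.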